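Nitro in Place of Fluoro on Compound 3

A few compounds are considered here, and "the series" means these few. Any claim that something is new, unique, unknown or untested is made for them only; others in the source may bear on it.

Of the compounds shown here, three built on one shared core have been measured in a functional assay on L1210 cells (Mus musculus) for cytotoxicity, with a stated time of 48 h; on this read-out higher numbers stand for weaker inhibition and lower numbers for stronger inhibition. Compound 1 `Fc1ccc(-c2nc3sc(Cc4ccc(Cl)cc4)nn3c2Br)cc1` gives only a limit of the assay, > 250000 nM, which is the limit of > 250000 nM in this assay, at which 1 of the 3 values shown sits. Compound 2 `O=Cc1c(-c2ccc(F)cc2)nc2sc(Cc3ccc(Cl)cc3)nn12` gives 20000 nM, and compound 3 `N#CSc1c(-c2ccc(F)cc2)nc2sc(Cc3ccc(Cl)cc3)nn12` gives 23000 nM. The step of a 1.2-fold higher number from compound 2 to compound 3 (0.06 log units; within the scatter) lies within the scatter, so compound 3 sits alongside compound 2 among the two numbers shown, with compound 1 contributing a limit only. The steps of an at least 12-fold lower number from compound 1 to compound 2 (1.09 log units; beyond the scatter) and an at least 10-fold lower number from compound 1 to compound 3 (1.03 log units; beyond the scatter) are large and both exchange the bromo group on the core.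

Compound 4 `N#CSc1c(-c2ccc([N+](=O)[O-])cc2)nc2sc(Cc3ccc(Cl)cc3)nn12` differs from compound 3 by nitro in place of fluoro on an aromatic carbon. Within the data shown here, none of the measured steps touches this ring: in each of them the 4-fluorophenyl group stays unchanged while the group on the core is exchanged. Among the measured compounds shown here, no measured step therefore bears on this change, and the expectation for compound 4 in this assay is a step of no size beyond the scatter, in neither direction. Compound 4 is expected to give 25000 nM, within a range from 8000 nM to 80000 nM. This estimate means an expected step of a 1.1-fold higher number from compound 3 to compound 4 (0.04 log units; within the scatter), which is expected to remain within the scatter.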

Compound 4, half-maximal inhibitory concentration: 50000 nM
Compound 4: the middle estimate sits 2.0-fold (0.30 log units) below what was measured, and the stated range covers the measured number.
By their numbers in this assay, from the lowest: compounds 2 and 3 (each within the scatter of the next); then compound 4. At a limit, above all of these: compound 1.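

Among these compounds, the first step to touch the 4-fluorophenyl group shows that this ring is not silent in this assay: a 2.2-fold higher number from compound 3 to compound 4 (0.34 log units; beyond the scatter). Nitro in place of fluoro thus moves the number modestly towards weaker inhibition, and compound 4 still gives a measured number rather than a limit. Nothing measured among these compounds offers a reason for this step.

As far as these compounds go, a single exchange on this ring sets no trend, so it remains open how an amine, a carboxylic acid or a methoxy group in the same place would read. From the compounds shown here alone, it also remains open whether the nitro for fluoro step would be the same size with the formyl group of compound 2 on the shared core instead of the cyanosulfanyl group.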